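A few compounds are considered here, and "the series" means these few. Any claim that something is new, unique, unknown or untested is made for them only; others in the source may bear on it.

Compound 1 is `COC1=C[C@H](O)[C@H](C/C=C(\C)CC/C=C(\C)CCC=C(C)C)[C@@H](C)C1=O`. In a functional assay on PC-3 cells (Homo sapiens) for inhibition, read by sulforhodamine B assay, with a stated time of 48 h (on this read-out higher numbers stand for weaker inhibition of growth and lower numbers for stronger inhibition of growth), compound 1 stops at a limit rather than a number, giving > 30000 nM. A second compound, compound 2, is `COC1=CC(=O)C(C/C=C(\C)CC/C=C(\C)CCC=C(C)C)=C(C)C1=O`. In this assay compound 2 likewise stops at a limit, giving > 30000 nM. Compound 1 therefore stands at no measured point: its record is the limit of > 30000 nM in this assay, at which 2 of the 2 values shown sit, and nothing separates it from compound 2 beyond that shared limit. Among the measured compounds shown here, no step between measured compounds can be drawn from these two values, and neither compound can be called stronger or weaker than the other.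

The compound still to be measured is compound 3, `COC1=C(OC)[C@H](O)[C@H](C/C=C(\C)CC/C=C(\C)CCC=C(C)C)[C@@H](C)C1=O`. It differs from compound 1 by methoxy in place of hydrogen on a double-bonded ring carbon. With both measured values sitting at a limit, no direction for this change can be read from the data. The expected step that the limit leaves unreadable from compound 1 to compound 3 is none beyond the scatter. The most likely outcome for compound 3 is another limit. Compound 3 is accordingly expected to give about 40000 nM, within a range from 15000 nM to 100000 nM.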

Compound 3, concentration for 50% growth inhibition: 13500 nM
Beside the measured number, compound 3's estimate is 3.0-fold (0.47 log units) above it, outside the stated range (below it).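

In this assay, methoxy in place of hydrogen on a double-bonded ring carbon, next to the ring atom that bears a hydroxy group, gives an at least 2.2-fold lower number from compound 1 to compound 3 (0.34 log units; beyond the scatter). This shows that the position is not silent: a change here can bring the core of compound 1 into the measurable range, which neither earlier compound could show, and compound 3 gives 13500 nM. The step can be stated only as a minimum because the starting point is a limit and not a number: the limit of > 30000 nM in this assay, at which 2 of the 3 values shown sit.

The compounds shown leave open how far the true value of compound 1 lies from its limit, and so how large the step really is, and whether methoxy is special at this ring carbon or whether ethoxy, a chlorine atom or an amine there would give a similar number. They also leave open whether the same methoxy would lower the number on the core of compound 2, and whether the large group or the hydroxy group must stay in place for compound 3 to keep its reading.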